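The source may report more compounds than this note shows. Statements on the series, on what has been measured and on what is new or still open speak of the compounds shown alone.

Series in a functional assay on PC-3 cells (Homo sapiens) for inhibition, read by sulforhodamine B assay; on this read-out lower numbers stand for stronger inhibition of growth and higher numbers for weaker inhibition of growth:
- compound 1 `Oc1cccc2[nH]c(-c3ccc(-c4ccc(-c5ccc(C(F)(F)F)cc5)cc4)cc3)nc12`: 2260 nM
- compound 2 `Oc1cccc2[nH]c(-c3ccc(-c4ccc(-c5ccc(OC(F)(F)F)cc5)cc4)cc3)nc12`: 7410 nM
- compound 3 `COc1ccc(-c2ccc(-c3ccc(-c4nc5c(O)cccc5[nH]4)cc3)cc2)cc1`: 6610 nM

Compound 3 gives 6610 nM, which is level with compound 2 within the scatter (a 1.1-fold lower number from compound 2 to compound 3 (0.05 log units; within the scatter)) and clearly weaker than compound 1 (a 2.9-fold higher number from compound 1 to compound 3 (0.47 log units; beyond the scatter)).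

Next is compound 4 `COc1ccc(-c2ccc(-c3ccc(-c4nc5c(O)cccc5[nH]4)cc3)cc2)cc1OC`, the change from 4-methoxyphenyl to 3,4-dimethoxyphenyl: methoxy in place of hydrogen on an aromatic carbon, ortho to a methoxy group and meta to a large group (methoxy in place of hydrogen on an aromatic carbon). Among the measured compounds shown here, no measured step adds a group at this place. For the measured compounds named here, the only guides are exchanges of one group for another on the same ring: a 3.3-fold higher number from compound 1 to compound 2 (0.52 log units; beyond the scatter) and a 2.9-fold higher number from compound 1 to compound 3 (0.47 log units; beyond the scatter), both modest, and a 1.1-fold lower number from compound 2 to compound 3 (0.05 log units; within the scatter), within the scatter. These give only a loose guide, so no step beyond the scatter is expected in this assay, and any drift would more likely be slightly upward. The expected change is a 1.2-fold higher number from compound 3 to compound 4 (0.08 log units; within the scatter), an estimate with an uncertain direction. For compound 4 the estimated value is 8000 nM, with an expected range of 3500 nM to 18000 nM.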

Compound 4, concentration for 50% growth inhibition: 1240 nM
Compound 4: middle estimate off by 6.5-fold (0.81 log units), on the high side, and the stated range ends above it.
By their numbers in this assay, from the lowest: compounds 4 and 1 (each within the scatter of the next); then compounds 3 and 2 (each within the scatter of the next).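

In this assay, among the compounds shown here, this is the first step that adds a group instead of exchanging one, and methoxy on an aromatic carbon, ortho to a methoxy group and meta to a large group, brings a gain beyond the scatter (a 5.3-fold lower number from compound 3 to compound 4 (0.73 log units; beyond the scatter)). The 3,4-dimethoxyphenyl group also improves on the 4-(trifluoromethoxy)phenyl group (a 6.0-fold lower number from compound 2 to compound 4 (0.78 log units; beyond the scatter)) and stands level with the 4-(trifluoromethyl)phenyl group (a 1.8-fold lower number from compound 1 to compound 4 (0.26 log units; within the scatter)), so the best level seen so far is no longer reached only with trifluoromethyl. Nothing available explains the gain.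

From the compounds shown here alone, whether the gain depends on the neighbouring methoxy group remains open. So does whether a hydroxy group, an amine or an ethoxy group at this place would give the same result.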